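Compound 4 carries a hydroxyethylphenyl amide in place of pyrazolyl

The source may report more compounds than this note shows. Statements on the series, on what has been measured and on what is new or still open speak of the compounds shown alone.

Measured so far:
compound 1, `C[C@@H](Cn1ccc(-c2ccc(C#N)c(Cl)c2)n1)NC(=O)c1ccccc1`: 1830 nM
compound 2, `COc1ccc(C(=O)N[C@@H](C)Cn2ccc(-c3ccc(C#N)c(Cl)c3)n2)cc1`: 3410 nM
compound 3, `CC(Cn1ccc(-c2ccc(C#N)c(Cl)c2)n1)C(=O)Nc1cc[nH]n1`: > 30000 nM

Three compounds share the chloro-nitrile aryl-pyrazole core. In a functional assay on LNCaP cells (Homo sapiens) for antiproliferative activity, read by CCK-8 assay, with a stated time of 6 days (on this read-out lower numbers stand for stronger inhibition and higher numbers for weaker inhibition), compound 1 gives 1830 nM and compound 2 gives 3410 nM; the methoxy in place of hydrogen on an aromatic carbon gives a 1.9-fold higher number from compound 1 to compound 2 (0.27 log units; within the scatter). Compound 3 reaches only the limit (the limit of > 30000 nM in this assay, at which 1 of the 3 values shown sits), so in this assay compound 3 stands at > 30000 nM, which is a limit of the assay and not a number; it is the weakest result shown, with no number attached.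

Compound 4, `CC(Cn1ccc(-c2ccc(C#N)c(Cl)c2)n1)C(=O)Nc1cccc(C(C)O)c1`, differs from compound 3 in one place: 3-(1-hydroxyethyl)phenyl in place of 1H-pyrazol-3-yl on an amide-type nitrogen. Going by the values given here, no measured step concerns this part of the molecule; the only measured step, the methoxy change from compound 1 to compound 2, touches a different position and lay within the scatter, so it offers no guide to size. Compounds 1 and 2, which carry an aryl amide, give numbers where compound 3 gives none, but they differ from compound 3 in more than one place and are not a measured step. The expectation for the step from compound 3 to compound 4 is therefore loose, an at least 2.0-fold lower number from compound 3 to compound 4 (0.30 log units; that floor lies within the scatter), towards a lower number. Compound 4 is estimated at 15000 nM, within 3000 nM to 30000 nM.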

Compound 4, half-maximal inhibitory concentration: 4150 nM
Beside the measured number, compound 4's estimate is 3.6-fold (0.56 log units) above it; the measured number falls inside the stated range.
By their numbers in this assay, from the lowest: compounds 1, 2 and 4 (each within the scatter of the next, the first and the last beyond it). At a limit, above all of these: compound 3.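

Going by these compounds alone, the change at this position, 3-(1-hydroxyethyl)phenyl in place of 1H-pyrazol-3-yl on an amide-type nitrogen, is the first measured step to lie beyond the scatter: in this assay it gives an at least 7.2-fold lower number from compound 3 to compound 4 (0.85 log units; beyond the scatter). The only earlier step, a 1.9-fold higher number from compound 1 to compound 2 (0.27 log units; within the scatter), touched a different place and gave no such guide, so this amide substituent is the first place shown where a single change separates a compound with a number, here compound 4 at 4150 nM, from one without. Compound 3 stands at a limit of the assay and not at a number, so only a floor for the step can be read, since its true size runs into that limit: the limit of > 30000 nM in this assay, at which 1 of the 4 values shown sits.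

On these data alone, whether the hydroxyl of the 1-hydroxyethyl group plays any part stays open, as does what an amine, a carboxylic acid or a longer chain in its place on the phenyl ring would do to the number. The compounds shown also give no reason why the phenyl amide reads so differently from the pyrazolyl amide.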